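Chloro for Trifluoromethyl in the Methoxy Urea Series

The source may hold more compounds than are shown below. What is called first, only, known or untested is meant among the compounds shown, and "the series" means these compounds.

Compound 1, `O=C(Nc1cccc(-n2cc(-c3ccncc3)c(-c3cc(O)cc(Cl)c3)n2)c1)Nc1ccc(Cl)c(C(F)(F)F)c1`: in a functional assay on PC-3 cells (Homo sapiens) for inhibition, read by sulforhodamine B assay, with a stated time of 48 h, tested at 0.01 uM (on this read-out lower numbers stand for a stronger effect and higher numbers for a weaker effect at the one concentration tested), compound 1 gives 95%.
Compound 2, `O=C(Nc1cccc(-n2cc(-c3ccncc3)c(-c3cc(O)cc(Cl)c3)n2)c1)Nc1ccc(Cl)c(Cl)c1`: in this assay compound 2 gives 90%.
Compound 3, `COc1cc(Cl)cc(-c2nn(-c3cccc(NC(=O)Nc4ccc(Cl)c(C(F)(F)F)c4)c3)cc2-c2ccncc2)c1`: in this assay compound 3 gives 94%.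

Compound 3 differs from compound 1 only by methyl in place of hydrogen on an oxygen on an aromatic ring, and the step of a number 1 percentage points lower from compound 1 to compound 3 (within the scatter) is within the scatter. The value of compound 2 also lies within the scatter of compound 3, so the three measured compounds cannot be ordered on these numbers.

Compound 4, `COc1cc(Cl)cc(-c2nn(-c3cccc(NC(=O)Nc4ccc(Cl)c(Cl)c4)c3)cc2-c2ccncc2)c1`, is the unmeasured partner of compound 3. The change is chloro in place of trifluoromethyl on an aromatic carbon. The same exchange has been seen once already, in the hydroxy pair: the step of a number 5 percentage points lower from compound 1 to compound 2 (within the scatter) was within the scatter. On that one precedent no step beyond the scatter is expected here, perhaps a small drift to a lower number. Compound 4 is therefore expected to give 90% in this assay, within a range from 82% to 98%. The step this estimate implies, a number 4 percentage points lower from compound 3 to compound 4 (within the scatter), is expected to stay within the scatter.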

Compound 4, a percentage reported as activity, at one concentration (the size of the read-out at that concentration, not a potency): 96%
Compound 4: the middle estimate sits 6 percentage points below what was measured; the measured number falls inside the stated range.
By their numbers in this assay, from the lowest: compounds 2, 3, 1 and 4 (each within the scatter of the next).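

In this assay, chloro in place of trifluoromethyl now has a second reading, a number 2 percentage points higher from compound 3 to compound 4 (within the scatter), and the two readings of this change agree: the same change on two cores in this assay, a number 5 percentage points lower (within the scatter) from compound 1 to compound 2 and a number 2 percentage points higher (within the scatter) from compound 3 to compound 4, 7 percentage points apart, within the scatter of two such steps. Methyl in place of hydrogen on the oxygen also has a second reading, a number 6 percentage points higher from compound 2 to compound 4 (within the scatter), and again the two readings agree: the same change on two cores in this assay, a number 1 percentage points lower (within the scatter) from compound 1 to compound 3 and a number 6 percentage points higher (within the scatter) from compound 2 to compound 4, 7 percentage points apart, within the scatter of two such steps. Neither change therefore separates any of the four compounds at the one concentration tested, whichever group stands at the other site.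

The compounds shown leave open whether any group at this position could move the read-out beyond the scatter at this concentration. A nitrile, an amine or a carboxylic acid in place of the chloro of compound 4 would be a further test, since all three lie outside the two groups compared here.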